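The source may report more compounds than this note shows. Statements on the series, on what has been measured and on what is new or still open speak of the compounds shown alone.

Measured compounds:
compound 1, `O=C(NCc1nn2c(Cc3ccccc3)nnc2s1)c1ccccc1`, in a functional assay on the whole organism (strain Wistar) for inhibition, with Rattus norvegicus as the target, read by paw edema, with stated times of 30 min and 2 h, at a dose of 20 mg/kg by the oral route (on this read-out higher numbers stand for more inhibition at the one dose given (going by the name of the read-out) and lower numbers for less inhibition), compound 1 gives 21.2%
compound 2, `c1ccc(Cc2nnc3sc(-c4ccccc4Oc4ccccc4)nn23)cc1`, in this assay compound 2 gives 41%
compound 3, `O=C(NCc1nn2c(COc3ccccc3)nnc2s1)c1ccccc1`, in this assay compound 3 gives 35.9%

Compound 1 and compound 3 share a core and differ in one place, (phenoxy in place of phenyl on a saturated chain carbon bound to an aromatic carbon), and in this assay this change made the step of a number 14.7 percentage points higher from compound 1 to compound 3 (beyond the scatter). Compound 2 sits on a different core; the difference between the two cores is not broken down here. Its value lies beyond the scatter only against compound 1, while against compound 3 the two numbers are within the scatter of each other.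

Compound 4, `c1ccc(OCc2nnc3sc(-c4ccccc4Oc4ccccc4)nn23)cc1`, has not yet been measured. It differs from compound 2 by phenoxy in place of phenyl on a saturated chain carbon bound to an aromatic carbon, the same change at the same place as between compound 1 and compound 3. Among the measured compounds shown here, since that change is known from only one measured pair, the expectation rests on a single step. The step from compound 2 to compound 4 is expected to be a number 11 percentage points higher from compound 2 to compound 4 (beyond the scatter), because compound 1 to compound 3 showed a number 14.7 percentage points higher from compound 1 to compound 3 (beyond the scatter). Compound 4 is therefore estimated at 52%, with an expected range from 38% to 66%.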

Compound 4, a percentage reported as inhibition, in the whole organism at one dose (the size of the read-out at that dose, not a potency): 54.8%
Beside the measured number, compound 4's estimate is 2.8 percentage points below it, within the range that was stated.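

In this assay, phenoxy in place of phenyl on a saturated chain carbon bound to an aromatic carbon gave a number 13.8 percentage points higher from compound 2 to compound 4 (beyond the scatter), and the change carried over from the core of compound 1 to the core of compound 2 at much the same size: the same change on two cores in this assay, a number 14.7 percentage points higher (beyond the scatter) from compound 1 to compound 3 and a number 13.8 percentage points higher (beyond the scatter) from compound 2 to compound 4, 0.9 percentage points apart, within the scatter of two such steps. On these two cores, then, the change from benzyl to phenoxymethyl moved the read-out the same way, by amounts that cannot be told apart. Among the compounds shown here, this rests on only two pairs, however, and it neither shows that the step would hold on any further core nor explains why the numbers rise.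

The compounds shown carry only phenyl or phenoxy at this place, so it remains open how an amine, a carboxylic acid or a longer chain would read there. From the compounds shown here alone, with each compound read at a single dose, it also remains open whether the step would look the same at other doses.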